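The source may report more compounds than this note shows. Statements on the series, on what has been measured and on what is new or still open speak of the compounds shown alone.

Notes on the series. Compound 3 `Oc1ccc2[nH]ncc2c1C(c1ccc(F)cc1)N1CCCCC1` and compound 1 `Oc1ccc2[nH]ncc2c1C(c1ccc(C(F)(F)F)cc1)N1CCCCC1` share one core; compound 2 `Oc1c(C(c2ccc(F)cc2)N2CCCCC2)ccc2ccoc12` and the not yet measured compound 4 `Oc1c(C(c2ccc(C(F)(F)F)cc2)N2CCCCC2)ccc2ccoc12` share another. The difference between the two cores is not broken down here. In an assay for inhibition of protein disulfide-isomerase (Homo sapiens), with a stated time of 1 h (a higher number here means a weaker inhibitor, a lower number a stronger inhibitor), compound 3 gives 350 nM. In this assay compound 1 gives 710 nM and compound 2 gives 560 nM; the values of compound 2 and compound 1, and of compound 2 and compound 3, lie within the scatter of each other, so no order is read between them.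

Compound 1 differs from compound 3 in one place: trifluoromethyl in place of fluoro on an aromatic carbon Across this change the measurement moved by a 2.0-fold higher number from compound 3 to compound 1 (0.31 log units; beyond the scatter).

Compound 4 differs from compound 2 in one place: trifluoromethyl in place of fluoro on an aromatic carbon The place is described in the same words for both pairs, so this is the same change made a second time, now on the core of compound 2. Among the compounds with values here, only that single earlier instance is available to rest on. In this assay the step is expected to be a 2.0-fold higher number from compound 2 to compound 4 (0.29 log units; within the scatter), because the same change once gave a 2.0-fold higher number from compound 3 to compound 1 (0.31 log units; beyond the scatter). Compound 4 is accordingly estimated at 1100 nM, with a likely range from 600 nM to 2200 nM.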

Compound 4, half-maximal inhibitory concentration: 300 nM
For compound 4 the middle estimate is 3.7-fold (0.56 log units) above the measured one; measured number outside the range, below it.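

On the core of compound 2, trifluoromethyl in place of fluoro gives, in this assay, a 1.9-fold lower number from compound 2 to compound 4 (0.27 log units; within the scatter), so the higher number seen on the other core does not recur. The change therefore cannot be carried from one core to the other in this series as a fixed shift, and the two steps disagree by more than their scatter: the same change on two cores in this assay, a 2.0-fold higher number (0.31 log units; beyond the scatter) from compound 3 to compound 1 and a 1.9-fold lower number (0.27 log units; within the scatter) from compound 2 to compound 4, 3.8-fold (0.58 log units) apart, beyond the scatter of two such steps

This does not establish a true reversal on the core of compound 2, as that step taken alone stays within the scatter, and two pairs give no account of what in the cores separates them.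

Still open, as far as these compounds go, is whether other groups in the same place, such as chloro, methoxy, nitrile or a carboxylic acid, also give different steps on the two cores. Also open, from the compounds shown here alone, is whether the disagreement extends beyond this single pair of groups, or whether further pairs on both cores would give matching steps.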